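Replacing the 4-fluoro-3-nitrophenyl group of compound 1

This account rests on a few compounds, and the source may have more. Where it says the series, first, only, none or still open, it means among the compounds named here.

Within the data shown here, only two compounds have numbers so far in a functional assay on DU-145 cells (Homo sapiens) for inhibition, read by trypan blue exclusion, with a stated time of 96 h (on this read-out lower numbers stand for stronger inhibition of growth and higher numbers for weaker inhibition of growth), and both share one core. Compound 1 (`Cc1ccc(CS/C(=C/c2ccc(F)c([N+](=O)[O-])c2)C(=O)c2ccc(Cl)c([N+](=O)[O-])c2)cc1`) gives 1000 nM as the lower of the two numbers, and compound 2 (`O=C(/C(=C\c1ccc(Br)cc1)SCc1ccc(F)cc1)c1ccc(Br)cc1`) gives 25000 nM in the same test, a gap beyond the scatter. Compound 1 therefore stands as the stronger growth inhibitor of this pair.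

The next compound to be read is compound 3 (`Cc1ccc(CS/C(=C/c2ccc(C(=O)O)cc2)C(=O)c2ccc(Cl)c([N+](=O)[O-])c2)cc1`). It keeps the rest of compound 1 and carries 4-carboxyphenyl in place of 4-fluoro-3-nitrophenyl on a double-bonded chain carbon bound to a double-bonded chain carbon.

Among the measured compounds shown here, no measured pair isolates this change or any other single change, so the data give no direct guide to its size in this assay. A step to a higher number, beyond the scatter, is the working expectation, and it is held loosely. The estimated step is a 4.0-fold higher number from compound 1 to compound 3 (0.60 log units; beyond the scatter) on this evidence. For compound 3 the expected value is 4000 nM with an estimated range from 1000 nM to 20000 nM in this test.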

Compound 3, concentration for 50% growth inhibition: 10000 nM
The estimate for compound 3 lay 2.5-fold (0.40 log units) below the measured number, within the range that was stated.
By their numbers in this assay, from the lowest: compound 1; then compound 3; then compound 2.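

In this assay, the series now has its first comparison of compounds that differ in one place: a 10-fold higher number from compound 1 to compound 3 (1.00 log units; beyond the scatter), with 4-carboxyphenyl in place of 4-fluoro-3-nitrophenyl on a double-bonded chain carbon bound to a double-bonded chain carbon. With the rest of compound 1 held fixed, this position is therefore not indifferent to the group it carries, and this change weakens growth inhibition by an amount beyond the scatter. Nothing available explains the size of this step or links it to any property of either group.

The change removes the fluorine and the nitro group and introduces the carboxylic acid in a single swap, so this one step cannot be divided among those three parts. As far as these compounds go, how a methyl ester, a primary amide or an amine would read at the same position remains open, as does whether the same change would give a step of similar size with the other parts of the core altered.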